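Estimating a pyridine swap in a weakly active series

The compounds below may be only part of what the source reports. "The series", "measured", "known", "first", "only" and "open" are said of these compounds alone.

Measured in a functional assay on LNCaP cells (Homo sapiens) for antiproliferative activity, read by propidium iodide staining, with a stated time of 96 h; a lower number here means a stronger inhibitor, a higher number a weaker inhibitor:
- Compound 1 `CC(O)(CSc1cccc(S(F)(F)(F)(F)F)c1)C(=O)Nc1ccc(S(F)(F)(F)(F)F)cc1`: 25000 nM
- Compound 2 `CC(O)(CSc1ccc(C(F)(F)F)cc1)C(=O)Nc1ccc(S(F)(F)(F)(F)F)cc1`: 17000 nM
- Compound 3 `CC(O)(CSc1cccc(C(F)(F)F)c1)C(=O)Nc1ccc(S(F)(F)(F)(F)F)cc1`: 18300 nM

At 18300 nM, compound 3 cannot be separated from either neighbour in this assay. Changing the group on the ring gave a 1.4-fold lower number from compound 1 to compound 3 (0.14 log units; within the scatter), and 3-(trifluoromethyl)phenyl in place of 4-(trifluoromethyl)phenyl gave a 1.1-fold higher number from compound 2 to compound 3 (0.03 log units; within the scatter). Compound 4 `CC(O)(CSc1ccc(C(F)(F)F)cn1)C(=O)Nc1ccc(S(F)(F)(F)(F)F)cc1` has 5-(trifluoromethyl)pyridin-2-yl in place of 3-(trifluoromethyl)phenyl on a sulfur. Within the data shown here, no measured step swaps a ring of carbon only for one with a hetero atom, so these two small steps are only indirect guides. The expected change is a 1.1-fold higher number from compound 3 to compound 4 (0.04 log units; within the scatter), nothing beyond the scatter. For compound 4 the estimated value is 20000 nM, with an expected range of 9000 nM to 40000 nM.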

Compound 4, half-maximal inhibitory concentration: 12300 nM
Estimate against measurement, compound 4: 1.6-fold (0.21 log units) above, within the range that was stated.
By their numbers in this assay, from the lowest: compounds 4, 2, 3 and 1 (each within the scatter of the next, the first and the last beyond it).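

Placing 5-(trifluoromethyl)pyridin-2-yl on the sulfur swaps a ring of carbon only for one holding a nitrogen, and in this assay this gives a 1.5-fold lower number from compound 3 to compound 4 (0.17 log units; within the scatter) and a 1.4-fold lower number from compound 2 to compound 4 (0.14 log units; within the scatter). Neither step exceeds the scatter, so among the compounds shown, this ring swap on the sulfur leaves the number indistinguishable from those of the carbon-only rings. Nothing available here offers an explanation for the result.

As far as these compounds go, whether a pyrimidine ring on the sulfur would move the number beyond the scatter stays open. The same holds for an amine or a carboxylic acid in place of the trifluoromethyl.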